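Replacing 2-Carboxyethenyl with 2-Chloro-1,3-thiazol-5-yl

A few compounds are considered here, and "the series" means these few. Any claim that something is new, unique, unknown or untested is made for them only; others in the source may bear on it.

Compound 1, `C=C(C)C(=O)Nc1cccc(-c2nc3ccccc3s2)c1`, reaches only the limit of an ADME assay on BJ cells (Homo sapiens) for inhibition, with a stated time of 72 h (a higher number here means that more compound is needed for the effect, a lower number that less compound is needed), > 25000 nM.
Compound 2, `O=C(O)/C=C/C(=O)Nc1cccc(-c2nc3ccccc3s2)c1`, likewise sits at the limit in this assay, > 25000 nM.
Compound 3, `CC(C)(CCl)C(=O)Nc1cccc(-c2nc3ccccc3s2)c1`, also stops at the limit, > 25000 nM.

All three values shown are limits rather than numbers, as the limit of > 25000 nM in this assay, at which 3 of the 3 values shown sit, records. The three compounds share one core and differ only in the group on the carbonyl carbon of the amide. Every value is a limit. None of the steps between them can therefore be read: a step that the two limits leave unreadable from compound 1 to compound 2, a step that the two limits leave unreadable from compound 1 to compound 3 and a step that the two limits leave unreadable from compound 2 to compound 3. Compound 2 therefore cannot be placed above or below its two neighbours; all that is known is that it is no more potent than the limit allows.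

Compound 4, `O=C(Nc1cccc(-c2nc3ccccc3s2)c1)c1cnc(Cl)s1`, is the next compound to be measured. It differs from compound 2 in one place: 2-chloro-1,3-thiazol-5-yl in place of 2-carboxyethenyl on a carbonyl carbon. The two measured steps that touch compound 2 both ran into the limit, so there is no readable step to lean on, and the three compounds give no sign that any change at this carbonyl carbon has brought potency into the measurable range. Compound 4 is therefore expected to land at or near the limit again, with 25000 nM estimated within 8000 nM to 60000 nM. That estimate means an expected step of a number no higher from compound 2 to compound 4 (the limit leaves the size open).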

Compound 4, half-maximal effective concentration: > 25000 nM
Compound 4: only a limit was reported; the forecaster's own chance of this, stated with the estimate: 75%; the middle value lies on the limit itself.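

In this assay compound 4 gives > 25000 nM, which is a limit and not a number. Its steps to compound 1, compound 2 and compound 3 therefore cannot be read, as all four compounds share one limit: the limit of > 25000 nM in this assay, at which 4 of the 4 values shown sit. The compounds shown leave open how these four compare with one another, and whether any group on this carbonyl carbon gives a measurable value.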